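Working notes: from ethyl to 4-bromobenzyl on the shared core

The source may report more compounds than this note shows. Statements on the series, on what has been measured and on what is new or still open speak of the compounds shown alone.

Measured in a functional assay on MDA-MB-231 cells (Homo sapiens) for antiproliferative activity, read by MTT assay, with a stated time of 48 h; on this read-out higher numbers stand for weaker inhibition and lower numbers for stronger inhibition
- compound 1 `O=C1N(Cc2ccc(Br)cc2)c2ccc(Cl)cc2C1(O)Cc1nnn[nH]1` gives > 100000 nM
- compound 2 `CN1C(=O)C(O)(Cc2nnn[nH]2)c2cc(Br)ccc21` gives 67300 nM
- compound 3 `CCN1C(=O)C(O)(Cc2nnn[nH]2)c2cc(Br)ccc21` gives > 100000 nM

Compound 3 gives > 100000 nM as a limit of the assay and not a number, so it stands at the limit of > 100000 nM in this assay, at which 2 of the 3 values shown sit, and no more can be said of its position. Compound 4 `O=C1N(Cc2ccc(Br)cc2)c2ccc(Br)cc2C1(O)Cc1nnn[nH]1` differs from it by 4-bromophenyl in place of methyl on a saturated chain carbon bound to an amide-type nitrogen in a ring, which is 4-bromophenyl in place of methyl on a saturated chain carbon bound to an amide-type nitrogen in a ring, or ethyl to 4-bromobenzyl. Among the measured compounds shown here, the only measured step at this place is an at least 1.4-fold higher number from compound 2 to compound 3 (0.17 log units; that floor lies within the scatter) and it offers no firm size to carry over. Compound 1 also carries 4-bromobenzyl. Compound 1 gives > 100000 nM as a limit too. No step beyond the scatter is therefore expected in this assay and the expected change is a number no higher from compound 3 to compound 4 (the limit leaves the size open) in plain terms. Compound 4 is expected at 100000 nM with an estimated range from 40000 nM to 250000 nM as its bounds.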

Compound 4, half-maximal inhibitory concentration: 65400 nM
Beside the measured number, compound 4's estimate is 1.5-fold (0.18 log units) above it; the range from low to high includes it.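

In this assay, the new value gives this position its first measured number with an aromatic ring in the group: a 1.0-fold lower number from compound 2 to compound 4 (0.01 log units; within the scatter), so the 4-bromophenyl change stays within the scatter. The two other steps rest on limits of the assay, an at least 1.5-fold lower number from compound 3 to compound 4 (0.18 log units; that floor lies within the scatter) and, for bromo in place of chloro on an aromatic carbon, an at least 1.5-fold lower number from compound 1 to compound 4 (0.18 log units; that floor lies within the scatter). Both floors lie within the scatter, so neither step has a firm size.

Going by these compounds, whether a longer chain ending in an amine, or a carboxylic acid, at this position would shift the number beyond the scatter remains open.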